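Triazolothiadiazine series: acyl aryl change, cytotoxicity

This account rests on a few compounds, and the source may have more. Where it says the series, first, only, none or still open, it means among the compounds named here.

Measured so far
- compound 1 `COc1cc(-c2nnc3n2NC(c2ccco2)C(C(=O)c2ccc(Br)cc2)S3)cc(OC)c1OC` in a functional assay on A549 cells (Homo sapiens) for cytotoxicity, read by MTT assay, with a stated time of 48 h; a higher number here means a weaker inhibitor, a lower number a stronger inhibitor: compound 1 gives 42100 nM
- compound 2 `COc1ccc(C(=O)C2Sc3nnc(-c4cc(OC)c(OC)c(OC)c4)n3NC2c2cccs2)cc1`: compound 2 gives > 100000 nM, which is a limit of the assay and not a number

Going by the values given here, compound 1 carries the only numeric value in this assay; the remaining value, that of compound 2, is a limit (the limit of > 100000 nM in this assay, at which 1 of the 2 values shown sits). Among the compounds with values here, no step between measured compounds that differ in one place is available, so no measured step size can be drawn on.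

Compound 3 `COc1cc(-c2nnc3n2NC(c2ccco2)C(C(=O)c2cccc4ccccc24)S3)cc(OC)c1OC` differs from compound 1 by naphthalen-1-yl in place of 4-bromophenyl on a carbonyl carbon. Within the data shown here, with no measured step to lean on, the expected step of a 1.2-fold higher number from compound 1 to compound 3 (0.07 log units; within the scatter) is small and is not expected to exceed the scatter in either direction. Compound 3 is therefore estimated at 50000 nM in this assay, within 15000 nM to 150000 nM, with a real chance that only a limit is reported.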

Compound 3, half-maximal inhibitory concentration: > 100000 nM
Compound 3: no number, only a limit; the forecaster's own chance of this, stated with the estimate: 35%; middle value at least 2.0-fold (0.30 log units) away from the limit.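

In this assay, this position on a carbonyl carbon now has a change with a readable direction: naphthalen-1-yl in place of 4-bromophenyl gives an at least 2.3-fold higher number from compound 1 to compound 3 (0.37 log units; beyond the scatter). Compound 3 reads > 100000 nM, which is a limit of the assay and not a number. The step therefore has a direction but no upper size, and compound 1 remains the only compound with a numeric value, with the limit now the more common reading: the limit of > 100000 nM in this assay, at which 2 of the 3 values shown sit.

The change removes the bromine and adds a second aromatic ring in one step, so the compounds shown cannot separate these two parts of it. Also open, as far as these compounds go, is whether a plain phenyl, a naphthalen-2-yl or a 4-aminophenyl on the same carbonyl carbon would give a number in this assay.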